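Demethylation on the aromatic nitrogen across two cores

The compounds below may be only part of what the source reports. "The series", "measured", "known", "first", "only" and "open" are said of these compounds alone.

Compound 3 `CN(c1ccc(Oc2ncnc3sccc23)cc1)c1nccc(N2CCCCC2)n1` gives 8790 nM in a functional assay on A549 cells (Homo sapiens) for inhibition, read by MTT assay, with a stated time of 72 h; a lower number here means a stronger inhibitor, a higher number a weaker inhibitor. Compound 1 `c1cc(N2CCCCC2)nc(Nc2ccc(Oc3ncnc4sccc34)cc2)n1` gives 4020 nM in this assay; the step of a 2.2-fold lower number from compound 3 to compound 1 (0.34 log units; beyond the scatter) goes with the change (hydrogen in place of methyl on a nitrogen on an aromatic ring). Compound 2 `CN(c1ccc(Oc2ncnc3ccsc23)cc1)c1nccc(N2CCc3ccccc3C2)n1` gives 16200 nM in this assay. The difference between the cores of compound 2 and compound 3 is not broken down here. Compound 4 `c1ccc2c(c1)CCN(c1ccnc(Nc3ccc(Oc4ncnc5ccsc45)cc3)n1)C2` awaits measurement in this assay; it differs from compound 2 by hydrogen in place of methyl on a nitrogen on an aromatic ring, the same change as before, with the place described in the same words. The step is expected to be about a 2.2-fold lower number from compound 2 to compound 4 (0.34 log units; beyond the scatter), because the same change gave a 2.2-fold lower number from compound 3 to compound 1 (0.34 log units; beyond the scatter) once on the other core, so the transfer rests on a single precedent. Compound 4 is estimated at 7400 nM in this assay, between 3000 nM and 18000 nM.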

Compound 4, half-maximal inhibitory concentration: 17000 nM
Compound 4: middle estimate off by 2.3-fold (0.36 log units), on the low side; the range from low to high includes it.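

Hydrogen in place of methyl on a nitrogen on an aromatic ring goes with a 1.0-fold higher number from compound 2 to compound 4 (0.02 log units; within the scatter) in this assay, so the step beyond the scatter seen on the other core does not recur here. Set side by side, the two steps cannot be told apart: the same change on two cores in this assay, a 2.2-fold lower number (0.34 log units; beyond the scatter) from compound 3 to compound 1 and a 1.0-fold higher number (0.02 log units; within the scatter) from compound 2 to compound 4, 2.3-fold (0.36 log units) apart, within the scatter of two such steps. For the compounds shown here, this gives no firm sign that the two cores respond differently, but it does not show that the change carries over at a constant size, as there are only two pairs and one step lies within the scatter.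

Still open, on these data alone, is how a longer chain such as ethyl, or an acetyl group, on that nitrogen would read in this assay. The separate contributions of the two cores also remain open, as no pair shown differs in the core alone.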